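The source may hold more compounds than are shown below. What is called first, only, known or untested is meant among the compounds shown, and "the series" means these compounds.

Of the compounds shown here, three built on one shared core have been measured in a functional assay on PC-3 cells (Homo sapiens) for inhibition; on this read-out higher numbers stand for weaker inhibition and lower numbers for stronger inhibition. Compound 1 `COc1cc2nc(N3CCN(S(=O)(=O)c4ccc(C(F)(F)F)cc4)CC3)nc(N)c2cc1OC` gives 27000 nM. Compound 2 `COc1ccc(S(=O)(=O)N2CCN(c3nc(N)c4cc(OC)c(OC)cc4n3)CC2)cc1` gives 39000 nM. Compound 3 `COc1cc2nc(N3CCN(S(=O)(=O)c4cc(Cl)ccc4Cl)CC3)nc(N)c2cc1OC` gives 60000 nM, the highest of the three numbers; its gap to compound 2 lies within the scatter, and only its gap to compound 1 is beyond it. Compound 4 `COc1cc2nc(N3CCN(S(=O)(=O)c4cc(F)c(Cl)c(C(=O)O)c4)CC3)nc(N)c2cc1OC` differs from compound 3 in one place: 3-carboxy-4-chloro-5-fluorophenyl in place of 2,5-dichlorophenyl on a sulfonyl sulfur. Earlier exchanges of the group on the sulfonyl sulfur moved the numbers little, a 2.2-fold higher number from compound 1 to compound 3 (0.35 log units; beyond the scatter) and a 1.5-fold higher number from compound 2 to compound 3 (0.19 log units; within the scatter). On that basis the step of a 1.2-fold lower number from compound 3 to compound 4 (0.08 log units; within the scatter) is expected to stay small in this assay, with no clear direction. Compound 4 is therefore estimated at 50000 nM, within a range from 18000 nM to 140000 nM.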

Compound 4, half-maximal inhibitory concentration: 56000 nM
The estimate for compound 4 lay 1.1-fold (0.05 log units) below the measured number; the measured number falls inside the stated range.
By their numbers in this assay, from the lowest: compounds 1, 2, 4 and 3 (each within the scatter of the next, the first and the last beyond it).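

In this assay, among these compounds, 3-carboxy-4-chloro-5-fluorophenyl on the sulfonyl sulfur brings a hydrogen-bond donor that the earlier groups lack, yet the steps of a 1.1-fold lower number from compound 3 to compound 4 (0.03 log units; within the scatter) and a 1.4-fold higher number from compound 2 to compound 4 (0.16 log units; within the scatter) show no separation from those compounds. Only a 2.1-fold higher number from compound 1 to compound 4 (0.32 log units; beyond the scatter) passes the scatter, and that step is modest. So at this position, even a larger group carrying a carboxylic acid leaves the number in the same narrow band. Nothing available explains this result. Still open, from the compounds shown here alone, is whether an amine or a longer chain on the aromatic ring would shift the number further.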